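Urea series: fluoro to hydrogen, cytotoxicity on Raji cells

The source may hold more compounds than are shown below. What is called first, only, known or untested is meant among the compounds shown, and "the series" means these compounds.

Measured so far:
compound 1 `CCc1ccc(NC(=O)Nc2cc(C)nc3ccccc23)cc1` — > 25000 nM
compound 2 `COc1ccc(NC(=O)Nc2cc(C)nc3ccccc23)cc1F` — > 25000 nM

Both numbers come from an ADME assay on Raji cells (Homo sapiens) for cytotoxicity, with a stated time of 72 h; a higher number here means that more compound is needed for the effect, a lower number that less compound is needed. For compound 1 the entry > 25000 nM is a limit of the assay, not a measured number. For compound 2 the entry > 25000 nM is likewise a limit and not a number. Going by the values given here, compound 2 therefore stands at the limit of > 25000 nM in this assay, at which 2 of the 2 values shown sit, and the two values show nothing about any order between them; no step between measured compounds can be sized from these data.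

The next compound, compound 3 `COc1ccc(NC(=O)Nc2cc(C)nc3ccccc23)cc1`, differs from compound 2 in one place: hydrogen in place of fluoro on an aromatic carbon.

Among the compounds with values here, with no measured step available and both neighbours sitting at the same limit, there is no indication that a single fluorine shifts the read-out. In this assay the expected step is a step that the limit leaves unreadable from compound 2 to compound 3, which is taken to lie within the scatter and to have no direction. Compound 3 is estimated at 30000 nM, within a range from 10000 nM to 100000 nM, and is most likely to be reported again as a limit rather than a number.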

Compound 3, half-maximal effective concentration: > 25000 nM
Compound 3: no number, only a limit (the forecaster's own chance of this, stated with the estimate: 80%); the middle value does not contradict the limit.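

Compound 3 gives only a limit, > 25000 nM, so the steps to it from compound 2 and from compound 1 cannot be read, and no order among the three can be drawn: the limit of > 25000 nM in this assay, at which 3 of the 3 values shown sit.

The compounds shown leave open whether hydrogen in place of fluoro, or methoxy in place of ethyl, makes any difference to the read-out.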